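A few compounds are considered here, and "the series" means these few. Any claim that something is new, unique, unknown or untested is made for them only; others in the source may bear on it.

Measured in a functional assay (aorta) for inhibition, with Rattus norvegicus as the target, with a stated time of 8 days (a higher number here means a weaker inhibitor, a lower number a stronger inhibitor), so far:
- compound 1 (`CCc1nsc(-c2ccc(N3CCN(c4cccc(C(F)(F)F)c4)CC3)nn2)n1`) gives 8 nM
- compound 2 (`Cc1nsc(-c2ccc(N3CCN(c4cccc(F)c4)CC3)nn2)n1`) gives 6 nM
- compound 3 (`Cc1nsc(-c2ccc(N3CCN(c4ccc(C(F)(F)F)cc4)CC3)nn2)n1`) gives 12 nM

A lower number here marks a stronger inhibitor, but small gaps mean little. Compound 2 at 6 nM stands within the usual scatter of both compound 1 and compound 3, so these values cannot be ranked against one another.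

The next compound is compound 4 (`Cc1nsc(-c2ccc(N3CCN(c4cc(Cl)cc(Cl)c4)CC3)nn2)n1`). It has 3,5-dichlorophenyl in place of the 3-fluorophenyl of compound 2 on an amine nitrogen in a ring (3,5-dichlorophenyl in place of 3-fluorophenyl on an amine nitrogen in a ring). For the measured compounds named here, no measured compound carries this new group, and no measured step shows what such a swap does, so the forecast is cautious. Going by the values given here, all three values so far lie close together, which gives no ground for expecting a large move in this assay in either direction. The expected outcome is no step beyond the scatter, with a slight lean towards a higher number (estimated step: a 1.7-fold higher number from compound 2 to compound 4 (0.22 log units; within the scatter)). For compound 4 the estimated value is 10 nM (expected range 4 nM to 30 nM).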

Compound 4, half-maximal inhibitory concentration: < 0.1 nM
Compound 4 ended at the assay's limit; the forecaster's own chance of this, stated with the estimate: 3%; middle value at least 100-fold (2.00 log units) away from the limit.
By their numbers in this assay, from the lowest: compounds 2, 1 and 3 (each within the scatter of the next). At a limit, below all of these: compound 4.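

In this assay, the group on the amine nitrogen in the six-membered ring can move the number much further than the three earlier values, each within the scatter of the next, gave any sign of: 3,5-dichlorophenyl in place of 3-fluorophenyl gives an at least 60-fold lower number from compound 2 to compound 4 (1.77 log units; beyond the scatter). For compound 4, the reading of < 0.1 nM is a limit of this assay and not a number: the limit of < 0.1 nM in this assay, at which 1 of the 4 values shown sits. This single swap changes both the kind of halogen and how many halogens the phenyl ring carries, and the step does not separate the two.

From the compounds shown here alone, it remains open whether a single chlorine would give a similar step, or whether methyl groups or bromine atoms in place of the chlorines would do the same. Also open, going by these compounds, is how an amine or a carboxylic acid on this phenyl ring would read in this assay.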